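A few compounds are considered here, and "the series" means these few. Any claim that something is new, unique, unknown or untested is made for them only; others in the source may bear on it.

Compound 1 `C=CCCn1c(=O)c2[nH]cnc2n(CCC)c1=O`: 60 nM in an assay on Cerebral cortex for binding affinity to adenosine receptor A1 (Cavia porcellus), read by radioligand binding; on this read-out higher numbers stand for weaker inhibition and lower numbers for stronger inhibition.
Compound 2 `CCCn1c(=O)n(CCC#N)c(=O)c2[nH]cnc21`: 15900 nM in this assay.

Going by the values given here, compound 1 stands at the lowest of the two numbers; the only other measured compound gives a 270-fold higher number from compound 1 to compound 2 (2.42 log units; beyond the scatter). Compound 3 `CCCn1c(=O)n(CCN(C)C)c(=O)c2[nH]cnc21` differs from compound 1 by dimethylamino in place of vinyl on a saturated chain carbon, two bonds along the chain from an aromatic nitrogen. Among the compounds with values here, the one measured step that bears on this change is the one from compound 1 to compound 2, where another group replaced the vinyl at the same place, and it was large. A weakening of similar character is therefore expected, estimated at a 50-fold higher number from compound 1 to compound 3 (1.70 log units; beyond the scatter). For compound 3 the expected value is 3000 nM, within 400 nM to 20000 nM.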

Compound 3, inhibition constant: 4300 nM
The estimate for compound 3 lay 1.4-fold (0.16 log units) below the measured number, within the range that was stated.
By their numbers in this assay, from the lowest: compound 1; then compound 3; then compound 2.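

In this assay dimethylamino gives a 72-fold higher number from compound 1 to compound 3 (1.86 log units; beyond the scatter) and so, like cyano, falls far short of vinyl at this place on the chain. The two replacements also differ from each other, with a 3.7-fold lower number from compound 2 to compound 3 (0.57 log units; beyond the scatter) on going from cyano to dimethylamino, so the outcome depends on which group enters and not only on vinyl leaving. Nothing measured here explains either step.

From the compounds shown here alone, whether a hydroxyl group or a longer chain ending in a carboxylic acid would bring the number back towards that of compound 1 stays open. So does whether any group here could give a lower number than vinyl.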